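The compounds below may be only part of what the source reports. "The series", "measured", "known", "first", "only" and "open" are said of these compounds alone.

Compounds measured in a functional assay on cells (Cancer cell lines, Homo sapiens) for cytotoxicity, read by sulforhodamine B assay, with a stated time of 48 h (a higher number here means a weaker inhibitor of growth, a lower number a stronger inhibitor of growth), so far:

compound 1, `COc1ccc(C2CC(c3ccccc3)=NN2C2=NC(=O)/C(=C3\C(=O)Nc4ccccc43)S2)cc1`, 1520 nM
compound 2, `COc1ccc(C2CC(c3ccc4ccccc4c3)=NN2C2=NC(=O)/C(=C3\C(=O)Nc4ccccc43)S2)cc1`, 360 nM
compound 3, `COc1ccc(C2CC(c3ccc4ccccc4c3)=NN2C2=NC(=O)/C(=C3\C(=O)Nc4ccc(Br)cc43)S2)cc1`, 59 nM

Compound 2 stands second highest of the three numbers. Its nearest neighbour is compound 1, and the step of a 4.2-fold lower number from compound 1 to compound 2 (0.63 log units; beyond the scatter) came with naphthalen-2-yl in place of phenyl on a carbon with a double bond to nitrogen. Its furthest neighbour is compound 3, where the step of a 6.1-fold lower number from compound 2 to compound 3 (0.79 log units; beyond the scatter) came with bromo in place of hydrogen on an aromatic carbon.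

Compound 4, `O=C1N=C(N2N=C(c3ccc4ccccc4c3)CC2c2ccc(Cl)cc2)S/C1=C1/C(=O)Nc2ccccc21`, has not yet been measured. It differs from compound 2 by chloro in place of methoxy on an aromatic carbon, that is, 4-methoxyphenyl to 4-chlorophenyl. Neither measured step touches this position; both change other parts of the shared core, so they give no direct guide to this exchange. For the measured compounds named here, with no comparable step available, the expectation for compound 4 in this assay is a number close to that of compound 2, within the scatter, expressed as the step of a 1.2-fold lower number from compound 2 to compound 4 (0.08 log units; within the scatter). The estimated value for compound 4 is 300 nM, with a range from 100 nM to 1000 nM.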

Compound 4, concentration for 50% growth inhibition: 400 nM
Compound 4: middle estimate off by 1.3-fold (0.12 log units), on the low side; measured number inside the range.
By their numbers in this assay, from the lowest: compound 3; then compounds 2 and 4 (each within the scatter of the next); then compound 1.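

In this assay, for the compounds shown here, the change from 4-methoxyphenyl to 4-chlorophenyl gave a 1.1-fold higher number from compound 2 to compound 4 (0.05 log units; within the scatter), which is the first reading at this position, since neither earlier step touched it. With the rest of the structure held fixed, chloro in place of methoxy left the number within the scatter, whereas the two earlier changes, made elsewhere on the shared core, both gave steps beyond it. No measurement offered here accounts for how closely the two groups agree. The compounds shown leave open whether an amine, a carboxylic acid or a longer alkoxy chain at this place on the ring would also leave the number within the scatter. They also leave open whether the gain seen with bromo on the core would carry over when chloro stands at this position.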